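Hydrazone variation at the amine nitrogen of the shared core

This account rests on a few compounds, and the source may have more. Where it says the series, first, only, none or still open, it means among the compounds named here.

Measured so far in a functional assay on HepG2 cells (Homo sapiens) for inhibition, read by MTT assay, with a stated time of 48 h; on this read-out lower numbers stand for stronger inhibition and higher numbers for weaker inhibition:
compound 1 `CCOC(=O)C1=C(N/N=C(/C#N)C(=O)OCC)Nc2[nH]nc(C)c2C1c1ccc(N(C)C)cc1` gives 46400 nM
compound 2 `CCOC(=O)C1=C(N/C=N/c2nnc(S(N)(=O)=O)s2)Nc2[nH]nc(C)c2C1c1ccc(N(C)C)cc1` gives 38100 nM
compound 3 `CCOC(=O)C1=C(N/N=C(/Cl)c2ccc([N+](=O)[O-])cc2)Nc2[nH]nc(C)c2C1c1ccc(N(C)C)cc1` gives 55500 nM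

Compound 1 stands second highest of these three numbers, with compound 3 nearest and compound 2 furthest, and all three sit within the scatter of one another, so no order among them is claimed.

Compound 4 `CCOC(=O)C(=NNC1=C(C(=O)OCC)C(c2ccc(N(C)C)cc2)c2c(C)n[nH]c2N1)C(=O)OCC` differs from compound 1 in the group on the amine nitrogen: a group of 12 heavy atoms (7 carbon, 1 nitrogen, 4 oxygen; no ring) in place of a group of 9 heavy atoms (5 carbon, 2 nitrogen, 2 oxygen; no ring), on an amine nitrogen.

Among the measured compounds shown here, the steps that bear on this are the earlier exchanges at the same amine nitrogen: a 1.2-fold lower number from compound 1 to compound 2 (0.09 log units; within the scatter), a 1.2-fold higher number from compound 1 to compound 3 (0.08 log units; within the scatter) and a 1.5-fold higher number from compound 2 to compound 3 (0.16 log units; within the scatter). Each of these, including the entry of a ring, left this assay unchanged beyond the scatter. A further exchange of the same kind is therefore expected to give no step beyond the scatter, that is a 1.0-fold lower number from compound 1 to compound 4 (0.00 log units; within the scatter).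

Compound 4 is accordingly estimated at 46000 nM, with a range of 20000 nM to 105000 nM.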

Compound 4, half-maximal inhibitory concentration: 80800 nM
Estimate against measurement, compound 4: 1.8-fold (0.24 log units) below; low and high end bracket the measured number.
By their numbers in this assay, from the lowest: compounds 2, 1, 3 and 4 (each within the scatter of the next, the first and the last beyond it).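

Among the compounds shown here, at the amine nitrogen of the shared core, compound 2 and compound 4 give the first step beyond the scatter in this assay, though a modest one (a 2.1-fold higher number from compound 2 to compound 4 (0.33 log units; beyond the scatter)). For the compounds shown here, the other new steps stay within the scatter (a 1.7-fold higher number from compound 1 to compound 4 (0.24 log units; within the scatter); a 1.5-fold higher number from compound 3 to compound 4 (0.16 log units; within the scatter)), so only this one pair separates. No measured evidence accounts for this step.

Still open, as far as these compounds go, is whether an amine or a carboxylic acid on this nitrogen would give a step beyond the scatter from compound 1. Whether any group here gives a large step also remains unsettled.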